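Swapping an Ethyl for a Hydroxyphenyl on the Core

The compounds below may be only part of what the source reports. "The series", "measured", "known", "first", "only" and "open" are said of these compounds alone.

Measured so far:
- compound 1, `CCc1nnc([S+]([O-])Cc2ncc(C)c(OC)c2C)o1`: 12000 nM
- compound 2, `COc1c(C)cnc(C[S+]([O-])c2nnc(-c3ccccc3)o2)c1C`: 7000 nM
- compound 3, `[O-][S+](Cc1ccccc1)c1nnc(-c2ccccc2O)o1`: 8000 nM

The three compounds were tested in a functional assay on HUVEC cells (Homo sapiens) for inhibition, read by ELISA; on this read-out higher numbers stand for weaker inhibition and lower numbers for stronger inhibition. Compound 1 gives the largest number of the three, yet compound 2 and compound 3 both lie within the usual scatter of it, so no real separation between them is shown. Among the measured compounds shown here, the one single-point step that is known, a 1.7-fold lower number from compound 1 to compound 2 (0.23 log units; within the scatter), stays within the scatter as well.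

Compound 4, `COc1c(C)cnc(C[S+]([O-])c2nnc(-c3ccccc3O)o2)c1C`, is compound 1 with one change: 2-hydroxyphenyl in place of ethyl on an aromatic carbon. The step from compound 1 to compound 2 bears on it directly, since both put an aromatic ring where the ethyl sat, and that step was small. Compound 3 carries the same 2-hydroxyphenyl group but differs from compound 4 elsewhere too, so its value can only hint. A small or no step beyond the scatter is therefore expected: a 1.7-fold lower number from compound 1 to compound 4 (0.23 log units; within the scatter). For compound 4 the expected value in this assay is 7000 nM, with a range from 3000 nM to 16000 nM.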

Compound 4, half-maximal inhibitory concentration: 10000 nM
The estimate for compound 4 lay 1.4-fold (0.15 log units) below the measured number, and the stated range covers the measured number.
By their numbers in this assay, from the lowest: compounds 2, 3, 4 and 1 (each within the scatter of the next).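

In this assay, the larger 2-hydroxyphenyl group can stand in place of ethyl on this aromatic carbon with a 1.2-fold lower number from compound 1 to compound 4 (0.08 log units; within the scatter) and no real separation from the ethyl compound. The new information on the added hydroxy comes from a 1.4-fold higher number from compound 2 to compound 4 (0.15 log units; within the scatter) and, as this step also lies within the scatter, hydroxy in place of hydrogen on the phenyl ring has no discernible effect on the number. No measurement shown here speaks to the reason these steps are small.

Going by these compounds, it remains open whether an amine, a carboxylic acid or a longer chain at this position would move the number beyond the scatter. It is also open whether any change to the shared core can separate compounds in this assay at all, as every step shown so far stays within the scatter.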